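The source may report more compounds than this note shows. Statements on the series, on what has been measured and on what is new or still open speak of the compounds shown alone.

Measured in a functional assay on MDA-MB-231 cells (Homo sapiens) for antiproliferative activity, read by MTT assay, with a stated time of 24 h; a higher number here means a weaker inhibitor, a lower number a stronger inhibitor:
- compound 1 `O=C(O)CC(NS(=O)(=O)c1ccc(OC(F)(F)F)cc1)c1ccccc1`: > 100000 nM, a limit
- compound 2 `CC(C)(C)c1ccc(C(CC(=O)O)NS(=O)(=O)c2ccccc2)cc1`: > 100000 nM, a limit
- compound 3 `CC(C)(C)c1ccc(C(CC(=O)O)NS(=O)(=O)c2ccc(C(F)(F)F)cc2)cc1`: 53700 nM

Among the compounds with values here, compound 3 holds the only actual number. Compound 1 and compound 2 stand at the limit of > 100000 nM in this assay, at which 2 of the 3 values shown sit.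

Next is compound 4 `CC(C)(C)c1ccc(C(CC(=O)O)NS(=O)(=O)c2ccc(OC(F)(F)F)cc2)cc1`, with this change: trifluoromethoxy in place of trifluoromethyl on an aromatic carbon. In words, trifluoromethoxy replaces trifluoromethyl on an aromatic carbon, para to a large group.

Within the data shown here, one measured step bears on this position: an at least 1.8-fold lower number from compound 2 to compound 3 (0.27 log units; that floor lies within the scatter). It replaces hydrogen rather than trifluoromethyl, and it gives no measured size for the exchange. No shift beyond the scatter is therefore expected in this assay, and no direction is favoured. The expected change is a 1.1-fold lower number from compound 3 to compound 4 (0.03 log units; within the scatter).

For compound 4 the estimate is 50000 nM, with an expected range of 20000 nM to 100000 nM.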

Compound 4, half-maximal inhibitory concentration: > 100000 nM
Compound 4 ended at the assay's limit; the forecaster's own chance of this, stated with the estimate: 25%; middle value at least 2.0-fold (0.30 log units) away from the limit.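

In this assay, trifluoromethoxy in place of trifluoromethyl on this aromatic carbon does not retain a measurable value (an at least 1.8-fold higher number from compound 3 to compound 4 (0.27 log units; that floor lies within the scatter)). The floor of that step lies within the scatter, so no real loss is established. Within the data shown here, the steps to compound 4 from compound 1 and compound 2 cannot be read, and the only actual number still belongs to compound 3: the limit of > 100000 nM in this assay, at which 3 of the 4 values shown sit.

On these data alone, the true size of the exchange remains open. So does whether a nitrile, an amine or a longer chain on this aromatic carbon would give a number below the limit.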